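The source may hold more compounds than are shown below. What is called first, only, known or untested is meant among the compounds shown, and "the series" means these compounds.

In an ADME assay on HEK293 cells (Homo sapiens) for cytotoxicity, read by reporter gene assay and resazurin assay, with a stated time of 48 h (a higher number here means that more compound is tolerated, a lower number that less compound is tolerated), compound 2 `COc1c(Br)cc(Br)cc1C(=O)Nc1ccc(Sc2nc3ccccc3s2)c(Cl)c1` gives > 100000 nM, which is a limit of the assay and not a number. Compound 1 `COc1c(Br)cccc1C(=O)Nc1ccccc1` gives > 100000 nM, also a limit. Compound 3 `COc1c(Br)cc(Br)cc1C(=O)Nc1cccc(Cl)c1` gives > 100000 nM, again a limit. For compound 2 this means (the limit of > 100000 nM in this assay, at which 3 of the 3 values shown sit), with no number to rank it by.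

Compound 4 `O=C(Nc1ccc(Sc2nc3ccccc3s2)c(Cl)c1)c1cc(Br)ccc1O` differs from compound 2 in one place, on a carbonyl carbon: a group of 8 heavy atoms (6 carbon, 1 oxygen, 1 bromine; one six-membered aromatic ring of carbon only) in place of a group of 10 heavy atoms (7 carbon, 1 oxygen, 2 bromine; one six-membered aromatic ring of carbon only), on a carbonyl carbon. For the measured compounds named here, the only measured step is a step that the two limits leave unreadable from compound 2 to compound 3, and it changes a different group. Going by the values given here, no measured step shows a fall in this assay, but none tests this exchange, so a modest fall is expected and a result at the limit remains quite possible. The step expected is an at least 3.3-fold lower number from compound 2 to compound 4 (0.52 log units; beyond the scatter). Compound 4 is estimated at 30000 nM, with an expected range of 5000 nM to 100000 nM.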

Compound 4, half-maximal cytotoxic concentration: 45000 nM
Compound 4: the middle estimate sits 1.5-fold (0.18 log units) below what was measured; measured number inside the range.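

On the carbonyl carbon, 5-bromo-2-hydroxyphenyl in place of the group with two bromines gives an at least 2.2-fold lower number from compound 2 to compound 4 (0.34 log units; beyond the scatter) in this assay. For the compounds shown here, this exchange therefore gives the first readable number, while the one earlier step, which changes a different group, cannot be read. Every other compound stays at a limit: the limit of > 100000 nM in this assay, at which 3 of the 4 values shown sit.

The compounds shown do not separate the lost bromine from the added hydrogen-bond donor. On these data alone, how an amine in place of the hydroxyl group would fare in this assay also stays open.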